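Shortening a side chain on two pyridazinone-type cores

A few compounds are considered here, and "the series" means these few. Any claim that something is new, unique, unknown or untested is made for them only; others in the source may bear on it.

Measured so far, in a functional assay on the whole organism (stomach) with Rattus norvegicus as the target; on this read-out lower numbers stand for an effect already at smaller amounts and higher numbers for an effect only at larger amounts of compound:
compound 1, `N=C(S)CCCCCCn1nc(-c2ccccc2)ccc1=O`, gives a limit of the assay, > 100 mg/kg.
compound 2, `N=C(S)CCCCCn1nc(-c2ccccc2)ccc1=O`, gives 23.3 mg/kg.
compound 3, `Cc1ccc(=O)n(CCCCC(=N)S)n1`, gives a limit of the assay, > 100 mg/kg.

The change from compound 1 to compound 2 is a group of 3 heavy atoms (1 carbon, 1 nitrogen, 1 sulfur; no ring) in place of a group of 4 heavy atoms (2 carbon, 1 nitrogen, 1 sulfur; no ring), on a saturated chain carbon, five bonds along the chain from an aromatic nitrogen. It gave an at least 4.2-fold lower number from compound 1 to compound 2 (0.63 log units; beyond the scatter). That the step is only a lower bound follows from the limit of > 100 mg/kg in this assay, at which 2 of the 3 values shown sit.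

Compound 4, `Cc1ccc(=O)n(CCCC(=N)S)n1`, is not yet measured. The change from compound 3 to compound 4 is a group of 3 heavy atoms (1 carbon, 1 nitrogen, 1 sulfur; no ring) in place of a group of 4 heavy atoms (2 carbon, 1 nitrogen, 1 sulfur; no ring), on a saturated chain carbon, three bonds along the chain from an aromatic nitrogen. It is the same kind of change as before, but it sits three bonds rather than five bonds along the chain from the aromatic nitrogen, and the two cores differ in a way that is not broken down here. Among the compounds with values here, since compound 3 shows only a limit, the expected step from compound 3 to compound 4 is an at least 1.6-fold lower number from compound 3 to compound 4 (0.22 log units; that floor lies within the scatter), with the earlier step from compound 1 to compound 2 as the only guide. Compound 4 is expected to give about 60 mg/kg, between 20 mg/kg and 150 mg/kg.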

Compound 4, dose for half-maximal effect: > 100 mg/kg
Compound 4 was reported as a limit; the forecaster's own chance of this, stated with the estimate: 50%; middle value at least 1.6-fold (0.22 log units) away from the limit.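

No step from compound 3 to compound 4 can be read, since both sit at the same limit: the limit of > 100 mg/kg in this assay, at which 3 of the 4 values shown sit.

Left open is whether the shorter chain changes the effect on this core at all, as it did on the core of compound 1.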